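Moving a fluorine on the sulfonyl aryl: clearance outlook

The source may report more compounds than this note shows. Statements on the series, on what has been measured and on what is new or still open speak of the compounds shown alone.

Measured so far:
Compound 1, `O=S(=O)(c1cccc(F)c1)c1cnc2c(F)cccc2c1-c1cccc(Cl)c1`: 0.56 mL/min
Compound 2, `O=S(=O)(c1cccc(F)c1)c1cnc2c(F)cccc2c1-c1ccccc1F`: 0.21 mL/min
Compound 3, `O=S(=O)(c1cccc(F)c1)c1cnc2c(F)cccc2c1-c1ccc(Cl)cc1`: 0.62 mL/min

These three compounds share one core and differ only in the aryl group attached to an aromatic carbon of that core. In an ADME assay on microsomes from liver (Homo sapiens) for metabolic stability, tested at 2.5 uM (on this read-out lower numbers stand for slow clearance and higher numbers for fast clearance), compound 1 gives 0.56 mL/min. Compound 3 sits within the scatter of compound 1, as the step of a 1.1-fold higher number from compound 1 to compound 3 (0.04 log units; within the scatter) shows, so the two cannot be told apart. Compound 2 is the one that stands out: the step of a 2.7-fold lower number from compound 1 to compound 2 (0.43 log units; beyond the scatter) is beyond the scatter, as is a 3.0-fold higher number from compound 2 to compound 3 (0.47 log units; beyond the scatter), so compound 2 is cleared noticeably more slowly than the other two.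

Compound 4, `O=S(=O)(c1ccc(F)cc1)c1cnc2c(F)cccc2c1-c1cccc(Cl)c1`, keeps the aryl group on the aromatic carbon that compound 1 carries and instead changes the group on the sulfonyl sulfur: 4-fluorophenyl in place of 3-fluorophenyl on a sulfonyl sulfur. Among the measured compounds shown here, no measured step touches that part of the molecule; every step so far changes the aryl on the aromatic carbon, and even those changes were modest at most. With nothing pointing to a shift in either direction, the expected step of a 1.0-fold lower number from compound 1 to compound 4 (0.01 log units; within the scatter) in this assay is within the scatter. Compound 4 is therefore estimated at 0.55 mL/min, expected to fall between 0.27 mL/min and 1.1 mL/min.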

Compound 4, intrinsic clearance in a liver preparation (reported as CLH), per the amount of preparation that the assay uses: 1.21 mL/min
The estimate for compound 4 lay 2.2-fold (0.34 log units) below the measured number, and the stated range ends below it.
By their numbers in this assay, from the lowest: compound 2; then compounds 1, 3 and 4 (each within the scatter of the next, the first and the last beyond it).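

Among the compounds shown here, this is the first change to the group on the sulfonyl sulfur, and it shows that this part of the molecule also matters in this assay: replacing 3-fluorophenyl with 4-fluorophenyl gives a 2.2-fold higher number from compound 1 to compound 4 (0.33 log units; beyond the scatter) and so moves the compound towards faster clearance. The step is modest, but the two groups have the same atoms, joined differently, and the same counts of hydrogen-bond donors and acceptors, so a rearrangement with no change in composition is enough to take the number beyond the scatter. Nothing available explains why the number rises at this position.

On these data alone, it remains open whether the same exchange on the sulfonyl sulfur would shift the number by a similar amount with a 2-fluorophenyl or 4-chlorophenyl on the aromatic carbon, as in compound 2 and compound 3, since only the 3-chlorophenyl case can be read here. Also open, as far as these compounds go, is how clearance would respond if the fluorophenyl on the sulfur gave way to an unsubstituted phenyl, a pyridine ring or a short alkyl chain.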